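The source may report more compounds than this note shows. Statements on the series, on what has been measured and on what is new or still open speak of the compounds shown alone.

Three compounds in this series share one core and differ only in the part that carries the acid. Compound 1 `O=C(O)c1cccc([C@H]2C[C@@H]2c2ccc(OCc3c(-c4c(Cl)cccc4Cl)noc3C3CC3)cc2Cl)c1`, compound 2 `O=C(O)c1cccc(N2CC(O)(c3ccc(OCc4c(-c5c(Cl)cccc5Cl)noc4C4CC4)cc3Cl)C2)c1` and compound 3 `O=C(O)c1cccc([C@H]2C[C@](OCCO)(c3ccc(OCc4c(-c5c(Cl)cccc5Cl)noc4C4CC4)cc3Cl)C2)c1` were all tested in an assay on isolated protein for agonist activity at Bile acid receptor (Homo sapiens), read by FRET; a higher number here means that more compound is needed for the effect, a lower number that less compound is needed. In this assay compound 1 gives 219 nM, compound 2 gives 54 nM and compound 3 gives 373 nM. Among these three numbers compound 1 holds the second highest; compound 3 sits nearest to it, within the usual scatter, so the two cannot be told apart, while compound 2 lies furthest from it with a lower number that is beyond the scatter.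

Compound 4 `O=C(O)c1cncc(C2CC2c2ccc(OCc3c(-c4c(Cl)cccc4Cl)noc3C3CC3)cc2Cl)c1` has not yet been measured. It differs from compound 1 in one place: 2-(5-carboxypyridin-3-yl)cyclopropyl in place of 2-(3-carboxyphenyl)cyclopropyl on an aromatic carbon. The six-membered aromatic ring that carries the acid thus holds one hetero atom in compound 4 where compound 1 has carbon only. Among the measured compounds shown here, no pair of measured compounds differs in exactly this way, so nothing in the data shows what such a swap does here. The expectation is a small step upward in number, a 1.6-fold higher number from compound 1 to compound 4 (0.20 log units; within the scatter), at about the edge of the scatter. Compound 4 is therefore estimated at 350 nM, with a range from 120 nM to 1000 nM.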

Compound 4, half-maximal effective concentration: 10 nM
Beside the measured number, compound 4's estimate is 35-fold (1.54 log units) above it; measured number below the stated range.
By their numbers in this assay, from the lowest: compound 4; then compound 2; then compounds 1 and 3 (each within the scatter of the next).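

The ring that carries the acid proves to be a very sensitive part of these molecules: exchanging one ring carbon for a nitrogen, while keeping the cyclopropyl link and the carboxylic acid, gives a 22-fold lower number from compound 1 to compound 4 (1.34 log units; beyond the scatter) in this assay and counts as a large change. Compound 1, compound 2 and compound 3 all have a ring of carbon only at this point, so they could not show that a hetero atom in this ring can matter so much. No measurement available here accounts for the size of this step.

Going by these compounds, compound 1 has two defined stereocentres and compound 4 has none recorded, so it remains open how much of the step belongs to the ring nitrogen and how much to the spatial arrangement of the cyclopropyl link. Also open, on these data alone, are whether a ring with two nitrogen atoms, or a tetrazole in place of the carboxylic acid, would keep this gain, and whether the same carbon-to-nitrogen exchange would have a similar effect on the acid-bearing parts of compound 2 and compound 3.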